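A few compounds are considered here, and "the series" means these few. Any claim that something is new, unique, unknown or untested is made for them only; others in the source may bear on it.

Compound 3 `CCCc1nc(-c2ccccc2)c(CNCCCN2CCN(c3ccc(C(F)(F)F)cc3)CC2)o1` gives 7250 nM in an assay on HEK293 cells for inhibition of Voltage-dependent T-type calcium channel subunit alpha-1G (Homo sapiens), read by patch clamp (on this read-out lower numbers stand for stronger inhibition and higher numbers for weaker inhibition), the highest of the three numbers measured; compound 1 `CCCc1nc(-c2ccccc2)c(CNCCCN2CCN(c3cccc(F)c3)CC2)o1` gives 3030 nM and compound 2 `CCCc1nc(-c2ccccc2)c(CNCCCN2CCN(c3ccccc3Cl)CC2)o1` gives 2800 nM. Compound 4 `CCCc1nc(-c2ccccc2)c(CNCCCN2CCN(c3cccc(C)c3)CC2)o1` differs from compound 3 by 3-methylphenyl in place of 4-(trifluoromethyl)phenyl on an amine nitrogen in a ring. Going by the values given here, two measured steps bear on this change: a 2.4-fold higher number from compound 1 to compound 3 (0.38 log units; beyond the scatter) and a 2.6-fold higher number from compound 2 to compound 3 (0.41 log units; beyond the scatter), both modest and beyond the scatter, while a 1.1-fold lower number from compound 1 to compound 2 (0.03 log units; within the scatter) lies within it. Since compound 4 carries a small group on the phenyl ring, like compound 1 with 3030 nM, the number is expected to fall back to about that level, a step of a 2.2-fold lower number from compound 3 to compound 4 (0.34 log units; beyond the scatter). Compound 4 is therefore estimated at 3300 nM, in a range from 1500 nM to 7000 nM.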

Compound 4, half-maximal inhibitory concentration: 1190 nM
Compound 4: middle estimate off by 2.8-fold (0.44 log units), on the high side; the measured number lies below the stated range.
By their numbers in this assay, from the lowest: compound 4; then compounds 2 and 1 (each within the scatter of the next); then compound 3.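

In this assay, going by these compounds alone, 3-methylphenyl is the first group on this amine nitrogen to stand apart at the low end: a 6.1-fold lower number from compound 3 to compound 4 (0.78 log units; beyond the scatter), a 2.4-fold lower number from compound 2 to compound 4 (0.37 log units; beyond the scatter) and a 2.5-fold lower number from compound 1 to compound 4 (0.41 log units; beyond the scatter), all beyond the scatter. The last of these is methyl in place of fluoro on an aromatic carbon, so exchanging that one group alone moves the number. Nothing measured here says why the number moves.

On these data alone, whether methoxy or a second methyl on the phenyl ring would go lower remains open. So does whether the 3-methylphenyl result holds with a longer chain on the other ring nitrogen.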